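A few compounds are considered here, and "the series" means these few. Any claim that something is new, unique, unknown or untested is made for them only; others in the source may bear on it.

Measured so far:
Compound 1, `CCC(=O)c1ccc2c(c1O)[C@H]1c3c(ccc4c(=O)c(C)coc34)OC[C@H]1C(C)(C)O2`: in a functional assay on MDA-MB-231 cells (Homo sapiens) for cytotoxicity, read by MTT assay (a lower number here means a stronger inhibitor, a higher number a weaker inhibitor), compound 1 gives only a limit, > 100000 nM.
Compound 2, `CC(=O)c1ccc2c(c1O)[C@H]1c3c(ccc4c(=O)c(C)coc34)OC[C@H]1C(C)(C)O2`: in this assay compound 2 likewise gives only a limit, > 100000 nM.
Compound 3, `CCC(=O)c1ccc2c(c1O)[C@@H]1c3c(ccc4c(=O)c(-c5ccccc5)c(C)oc34)OC[C@@H]1C(C)(C)O2`: in this assay compound 3 gives 6150 nM.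

Compound 1 and compound 2 differ in one change, (hydrogen in place of methyl on a saturated chain carbon bound to a carbonyl carbon). The step it made, a step that the two limits leave unreadable from compound 1 to compound 2, cannot be sized because both compounds sit at the limit of > 100000 nM in this assay, at which 2 of the 3 values shown sit. Compound 3 carries a different core; how the cores of compound 1 and compound 3 differ is not broken down here, and of the three compounds only compound 3 gives a number rather than a limit.

Compound 4, `CC(=O)c1ccc2c(c1O)[C@@H]1c3c(ccc4c(=O)c(-c5ccccc5)c(C)oc34)OC[C@@H]1C(C)(C)O2`, is not yet measured. It differs from compound 3 by hydrogen in place of methyl on a saturated chain carbon bound to a carbonyl carbon, the same change as between compound 1 and compound 2, at the same place. That earlier change gave no readable step, so no size carries over from it. Going by the values given here, the step from compound 3 to compound 4 is expected to be small, a 1.1-fold higher number from compound 3 to compound 4 (0.06 log units; within the scatter), resting mainly on compound 3 at 6150 nM as the only number available. Compound 4 is therefore estimated at 7000 nM, with a range from 2500 nM to 20000 nM.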

Compound 4, half-maximal inhibitory concentration: 46800 nM
For compound 4 the middle estimate is 6.7-fold (0.83 log units) below the measured one; measured number outside the range, above it.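

On the core of compound 3, going from propanoyl to acetyl gives a readable result in this assay, with a 7.6-fold higher number from compound 3 to compound 4 (0.88 log units; beyond the scatter), so the change is not neutral on this core. The same change on the core of compound 1 cannot be read, and the two cores cannot be compared for the size of this step, because compound 1 and compound 2 both give only a limit of the assay: the limit of > 100000 nM in this assay, at which 2 of the 4 values shown sit. One readable step on one core shows that the change can matter, but not that it carries over from one core to another with a set size or even a set direction.

Open on the core of compound 3 is whether a longer chain such as butanoyl in place of propanoyl would extend the step in the other direction in this assay. Also open, as far as these compounds go, is how an amine or a carboxylic acid on that saturated chain carbon bound to a carbonyl carbon would read there.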